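Benzylamino entry on the chloro quinone core of compound 1

A few compounds are considered here, and "the series" means these few. Any claim that something is new, unique, unknown or untested is made for them only; others in the source may bear on it.

Among the compounds with values here, in an ADME assay on Vero cells (Chlorocebus sabaeus) for cytotoxicity, read by MTT assay, with a stated time of 48 h (on this read-out higher numbers stand for weaker inhibition and lower numbers for stronger inhibition), compound 1 `CC(C)=CCCc1ccc2c(c1)C(=O)C(Cl)=CC2=O` gives 26.1 ug/mL, the only plain number among the three values shown. For compound 2 `COc1cc(OC)cc(OC2=CC(=O)c3ccc(CCCC(C)C)cc3C2=O)c1` this assay reports only a limit, <= 25 ug/mL. For compound 3 `CC(C)CCCc1ccc2c(c1)C(=O)C(Br)=C(Br)C2=O` this assay likewise reports a limit, <= 25 ug/mL. Within the data shown here, both of these rest at the limit of <= 25 ug/mL in this assay, at which 2 of the 3 values shown sit, so no step between measured compounds can be read, and no two measured compounds differ in a single place.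

Compound 4 `CC(C)=CCCc1ccc2c(c1)C(=O)C(Cl)=C(NCc1ccccc1)C2=O` is not yet measured in this assay. It differs from compound 1 by benzylamino in place of hydrogen on a double-bonded ring carbon; the shared core of compound 1 is otherwise kept. Among the measured compounds shown here, with no measured step as guide, the step expected in this assay from compound 1 to compound 4 is a 1.3-fold lower number from compound 1 to compound 4 (0.12 log units; within the scatter), a small move toward stronger inhibition that is not expected to exceed the usual scatter. Compound 4 is therefore estimated at 20 ug/mL, with a range from 6 ug/mL to 60 ug/mL. A reported limit instead of a number remains a real possibility for compound 4, given that two values already sit at the limit of <= 25 ug/mL in this assay, at which 2 of the 3 values shown sit.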

Compound 4, half-maximal inhibitory concentration: 55.9 ug/mL
For compound 4 the middle estimate is 2.8-fold (0.45 log units) below the measured one; low and high end bracket the measured number.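

In this assay the series now has its first readable step: benzylamino in place of hydrogen on a double-bonded ring carbon gives a 2.1-fold higher number from compound 1 to compound 4 (0.33 log units; beyond the scatter). The change therefore moves toward weaker inhibition, and the size of the move is modest. For this one pair, the carbon next to the ring atom that bears a chloro group can carry benzylamino, with its six-membered aromatic ring, without a gain in cytotoxicity on this read-out.

Steps involving compound 2 and compound 3 cannot be read: the limit of <= 25 ug/mL in this assay, at which 2 of the 4 values shown sit.
As far as these compounds go, whether the same direction holds for a smaller group on this carbon, such as methylamino, or for a benzylamino group carrying a carboxylic acid on its aromatic ring, stays open.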